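Removing the Methyl from the Thioether of Compound 1

This account rests on a few compounds, and the source may have more. Where it says the series, first, only, none or still open, it means among the compounds named here.

Compound 1 `COc1ccc(CNc2nc(SC)nc3ccccc23)cc1` was examined in a functional assay on MCF7 cells (Homo sapiens) for cytotoxicity, read by MTT assay, with a stated time of 72 h (a higher number here means a weaker inhibitor of growth, a lower number a stronger inhibitor of growth), where compound 1 gives 85100 nM. Of the two plain numbers shown it is the highest, with compound 3 `CSc1nc(NCc2ccccc2)c2ccccc2n1` nearest at 82800 nM; the step of a 1.0-fold lower number from compound 1 to compound 3 (0.01 log units; within the scatter) lies within the scatter. Compound 2 `C[Se]c1nc(N)c2cccnc2n1` reached only a limit, > 100000 nM, in this assay (the limit of > 100000 nM in this assay, at which 1 of the 3 values shown sits).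

Compound 4 `COc1ccc(CNc2nc(S)nc3ccccc23)cc1` has not yet been measured and differs from compound 1 by hydrogen in place of methyl on a sulfur. Among the compounds with values here, the only measured step, from compound 1 to compound 3, concerns a methoxy on an aromatic carbon and was within the scatter; no measured step touches the sulfur. The step from compound 1 to compound 4 is therefore expected to be a 1.1-fold higher number from compound 1 to compound 4 (0.02 log units; within the scatter), no larger than the scatter. Compound 4 is estimated to give 90000 nM in this assay, between 40000 nM and 200000 nM.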

Compound 4, concentration for total growth inhibition: 36500 nM
Compound 4: the middle estimate sits 2.5-fold (0.39 log units) above what was measured; measured number outside the range, below it.
By their numbers in this assay, from the lowest: compound 4; then compounds 3 and 1 (each within the scatter of the next). At a limit, above all of these: compound 2.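

Within the data shown here, the sulfur, which no earlier step had touched, proves to be a place where a single change moves the number in this assay: methylsulfanyl to sulfanyl gives a 2.3-fold lower number from compound 1 to compound 4 (0.37 log units; beyond the scatter), whereas the one earlier step, at the methoxy, gave a 1.0-fold lower number from compound 1 to compound 3 (0.01 log units; within the scatter). Nothing among the data shown gives a reason for this step. The compounds shown leave open whether an ethyl group or a longer chain on the sulfur, or an amine in place of the sulfanyl, would shift the number further. Also open, going by these compounds, is whether the same change on compound 3 would give a similar step.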